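Single-point inhibition across substituents on the shared core

A few compounds are considered here, and "the series" means these few. Any claim that something is new, unique, unknown or untested is made for them only; others in the source may bear on it.

Compound 1 `OC(Cc1ccccc1)c1cccc2[nH]ncc12` carries hydrogen at the position that varies in this set; in an assay for inhibition of Indoleamine 2,3-dioxygenase 1 (Homo sapiens), read by spectrophotometry, with a stated time of 30 min, tested at 10 uM (on this read-out higher numbers stand for more inhibition at the one concentration tested (going by the name of the read-out) and lower numbers for less inhibition), compound 1 gives 13%. Compound 2 `OC(Cc1ccccc1)c1cc(Br)cc2[nH]ncc12` gives 90%, and compound 3 `CCc1cc(C(O)Cc2ccccc2)c2cn[nH]c2c1` gives 70%. Compound 3 stands second highest of the three numbers: compound 2 is the nearest, and the gap is beyond the scatter, while compound 1 is furthest. The steps were a number 77 percentage points higher from compound 1 to compound 2 (beyond the scatter) and a number 57 percentage points higher from compound 1 to compound 3 (beyond the scatter), so either substituent in place of hydrogen raised the read-out strongly; the step of a number 20 percentage points lower from compound 2 to compound 3 (beyond the scatter) shows ethyl a modest way behind bromo.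

Compound 4 `OC(Cc1ccccc1)c1cc(-c2ccccc2)cc2[nH]ncc12` is not yet measured. The change from compound 3 is phenyl in place of ethyl on an aromatic carbon. Within the data shown here, the steps that bear on it are the two large additions at this position, both of which lifted inhibition well beyond the scatter, and the modest difference between the two substituents already tried. Among the measured compounds shown here, no measured step covers a group of this size here, so the direction for compound 4 is not fixed by the data; a step no larger than the scatter, or a small rise, is expected, a number 5 percentage points higher from compound 3 to compound 4 (within the scatter). Compound 4 is therefore estimated at 75%, with a range from 45% to 95%.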

Compound 4, a percentage reported as inhibition, at one concentration (the size of the read-out at that concentration, not a potency): 4%
Beside the measured number, compound 4's estimate is 71 percentage points above it; measured number below the stated range.
By their numbers in this assay, from the lowest: compounds 4 and 1 (each within the scatter of the next); then compound 3; then compound 2.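

At this aromatic carbon, the gain in this assay seen with bromo and ethyl does not extend to every group: phenyl, with 6 heavy atoms and a six-membered aromatic ring, gives a number 66 percentage points lower from compound 3 to compound 4 (beyond the scatter) when it replaces ethyl and a number 86 percentage points lower from compound 2 to compound 4 (beyond the scatter) when it replaces bromo. Against hydrogen, phenyl gives a number 9 percentage points lower from compound 1 to compound 4 (within the scatter) and so cannot be told apart from the unsubstituted compound, which means that the large rises from compound 1 belong to particular substituents and not to any replacement of hydrogen at this position. No measurement at hand accounts for this loss of inhibition.

The compounds shown leave open whether the loss follows the count of heavy atoms or the presence of the aromatic ring, a question that a longer chain such as butyl or a saturated ring such as cyclohexyl at the same carbon could separate. They also leave open whether a smaller ring such as cyclopropyl, or a group carrying heteroatoms such as an amine or a carboxylic acid, keeps the inhibition seen with bromo and ethyl.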